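The source may report more compounds than this note shows. Statements on the series, on what has been measured and on what is new or still open speak of the compounds shown alone.

Measured compounds in a functional assay on HepG2 cells (Homo sapiens) for antiproliferative activity, read by MTT assay, with a stated time of 72 h; a lower number here means a stronger inhibitor, a higher number a weaker inhibitor:
Compound 1 `CC/C=C\C(=O)Nc1cc(Nc2nccc(-c3cn(C)c4ccccc34)n2)c(OC)cc1N(C)CCN(C)C` gives 6670 nM.
Compound 2 `C=CC(=O)Nc1cc(Nc2nc(C)cc(-c3cn(C)c4ccccc34)n2)c(OC)cc1N(C)CCN(C)C` gives 12600 nM.
Compound 3 `C=CC(=O)Nc1cc(Nc2nccc(-c3cn(C)c4ccc(F)cc34)n2)c(OC)cc1N(C)CCN(C)C` gives 429 nM.

Among these three, compound 3 has the lowest number, and its separation from compound 1 and from compound 2 is beyond the usual scatter, so it is the strongest inhibitor of the set. Compound 4 `CC/C=C\C(=O)Nc1cc(Nc2nccc(-c3cn(C)c4ccc(F)cc34)n2)c(OC)cc1N(C)CCN(C)C` keeps the core of compound 3 and changes only the group on the amide carbonyl: but-1-en-1-yl in place of vinyl on a carbonyl carbon. Among the measured compounds shown here, no pair among the measured compounds isolates this change, so the step cannot be read directly from the data. Compound 1, which also carries but-1-en-1-yl but lacks the fluorine, shows a high number, yet two features differ there. Compound 4 is expected to be somewhat weaker than compound 3, by a step of a 2.8-fold higher number from compound 3 to compound 4 (0.45 log units; beyond the scatter) in this assay. Compound 4 is therefore estimated at 1200 nM, within a range from 400 nM to 4000 nM.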

Compound 4, half-maximal inhibitory concentration: 5290 nM
Beside the measured number, compound 4's estimate is 4.4-fold (0.64 log units) below it; the whole stated range lies below it.
By their numbers in this assay, from the lowest: compound 3; then compounds 4, 1 and 2 (each within the scatter of the next, the first and the last beyond it).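

In this assay, the longer but-1-en-1-yl group on the carbonyl carbon is far less well tolerated than vinyl when the fluorine is present, giving a 12-fold higher number from compound 3 to compound 4 (1.09 log units; beyond the scatter). With but-1-en-1-yl in place, fluoro in place of hydrogen on an aromatic carbon gives a 1.3-fold lower number from compound 1 to compound 4 (0.10 log units; within the scatter), so the fluorine brings no readable gain in this pair. Nothing measured here explains either step. Still open, going by these compounds, is how a prop-1-en-1-yl or ethynyl group on this carbonyl carbon would compare. Also open, on these data alone, is whether fluoro counts for anything when vinyl occupies that place.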